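The source may report more compounds than this note shows. Statements on the series, on what has been measured and on what is new or still open speak of the compounds shown alone.

Compound 1 `COc1cc(/C=C/C(=O)c2cccc(NC(=O)c3ccc(Cl)cc3)c2)ccc1O`: 2.3 ug/mL
Compound 2 `COc1cc(/C=C/C(=O)c2cccc(NC(=O)c3ccco3)c2)ccc1O`: 0.76 ug/mL

In a functional assay on SiHa cells (Homo sapiens) for inhibition (a higher number here means a weaker inhibitor, a lower number a stronger inhibitor), compound 2 gives the lower of the two numbers, 0.76 ug/mL. Compound 3 `COc1cc(/C=C/C(=O)c2cccc(NC(=O)c3ccc(Cl)cc3Cl)c2)ccc1O` differs from it as follows: 2,4-dichlorophenyl in place of furan-2-yl on a carbonyl carbon. That puts 2,4-dichlorophenyl in place of furan-2-yl on a carbonyl carbon. For the measured compounds named here, the only measured step that bears on this is modest: a 3.0-fold lower number from compound 1 to compound 2 (0.48 log units; beyond the scatter). Going by the values given here, compound 3 resembles compound 1, with its 4-chlorophenyl, at 2.3 ug/mL, though no measured compound carries 2,4-dichlorophenyl. A step of similar size towards a higher number is therefore expected: a 3.2-fold higher number from compound 2 to compound 3 (0.50 log units; beyond the scatter). The estimated value for compound 3 is 2.4 ug/mL, with an expected range of 0.9 ug/mL to 6 ug/mL.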

Compound 3, half-maximal inhibitory concentration: 34.4 ug/mL
For compound 3 the middle estimate is 14-fold (1.16 log units) below the measured one; measured number above the stated range.
By their numbers in this assay, from the lowest: compound 2; then compound 1; then compound 3.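

Adding a single chloro to the 4-chlorophenyl group gives a 15-fold higher number from compound 1 to compound 3 (1.17 log units; beyond the scatter) in this assay, so a small change on this carbonyl carbon can shift the number far more than the earlier pair showed. Replacing furan-2-yl with 2,4-dichlorophenyl gives a 45-fold higher number from compound 2 to compound 3 (1.66 log units; beyond the scatter), a much larger step than the first one seen at this place. Nothing available explains the size of these steps.

The compounds shown leave open how a plain phenyl group, or a phenyl ring carrying an amine, would compare on this carbonyl carbon. They also leave open whether the chloro's effect depends on where it sits on the ring.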